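The source may report more compounds than this note shows. Statements on the series, on what has been measured and on what is new or still open speak of the compounds shown alone.

Measured in a functional assay on the whole organism for antagonist activity, with Mus musculus as the target; a higher number here means that more compound is needed for the effect, a lower number that less compound is needed:
- compound 1 `CC(C#CCn1ccnc1)N1CCCC1=O`: 2 mg/kg
- compound 2 `CC1CCC(=O)N1CC#CCn1ccnc1`: 0.54 mg/kg
- compound 3 `Cc1cncn1CC#CCN1C(=O)CCC1C`: 0.8 mg/kg

Compound 2 sits clearly under compound 1 and level with compound 3, since a 1.5-fold higher number from compound 2 to compound 3 (0.17 log units; within the scatter). Compound 4 `CC1CCC(=O)N1CC#CCN(C)C` has dimethylamino in place of 1H-imidazol-1-yl on a saturated chain carbon bound to a triple-bonded carbon. For the measured compounds named here, only one measured step touches the group that leaves, and it adds a methyl without replacing the ring: a 1.5-fold higher number from compound 2 to compound 3 (0.17 log units; within the scatter). Going by the values given here, no measured step covers the swap itself, so the size is poorly constrained. A moderate move to a higher number in this assay is expected, namely a 3.7-fold higher number from compound 2 to compound 4 (0.57 log units; beyond the scatter). Compound 4 is estimated at 2 mg/kg, with an expected range of 0.4 mg/kg to 12 mg/kg.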

Compound 4, dose for half-maximal effect: > 100 mg/kg
Compound 4: only a limit was reported; the forecaster's own chance of this, stated with the estimate: 20%; at least 50-fold (1.69 log units) between middle value and limit.
By their numbers in this assay, from the lowest: compounds 2 and 3 (each within the scatter of the next); then compound 1. At a limit, above all of these: compound 4.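

In this assay compound 4 gives > 100 mg/kg, which is a limit and not a number. Dimethylamino in place of 1H-imidazol-1-yl on a saturated chain carbon bound to a triple-bonded carbon gives an at least 180-fold higher number from compound 2 to compound 4 (2.26 log units; beyond the scatter), the first change in the series to reach a limit of the assay. Adding a methyl to the retained ring gave only a 1.5-fold higher number from compound 2 to compound 3 (0.17 log units; within the scatter), so the ring tolerates that change, whereas its replacement by dimethylamino does not hold the effect.

Open, on these data alone, is whether any ring at this place suffices or only an aromatic one. A pyrrolidine and a pyrazole on the same chain carbon would separate these two readings.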